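A few compounds are considered here, and "the series" means these few. Any claim that something is new, unique, unknown or untested is made for them only; others in the source may bear on it.

Measured compounds:
- compound 1, `COC1=C(OC)[C@H](O)[C@H](C/C=C(\C)CC/C=C(\C)C[C@H](O)/C=C(\C)CO)[C@@H](C)C1=O`, in a functional assay on PC-3 cells (Homo sapiens) for inhibition, read by sulforhodamine B assay, with a stated time of 48 h; a lower number here means a stronger inhibitor of growth, a higher number a weaker inhibitor of growth: > 30000 nM, a limit of the assay
- compound 2, `COC1=C[C@H](O)[C@H](C/C=C(\C)CC/C=C(\C)C[C@H](O)/C=C(\C)CO)[C@@H](C)C1=O`, in this assay: > 30000 nM, a limit of the assay
- compound 3, `COC1=C(OC)[C@H](O)[C@H](C/C=C(\C)CC/C=C(\C)C/C=C/C(C)(C)O)[C@@H](C)C1=O`, in this assay: > 30000 nM, a limit of the assay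

All three measured compounds sit at the same limit of this assay, as the limit of > 30000 nM in this assay, at which 3 of the 3 values shown sit, records, so compound 1 holds no readable position among them: no number is known for it, only that it lies beyond the limit. Neither measured step gives a size; the change a step that the two limits leave unreadable from compound 1 to compound 2 and the change a step that the two limits leave unreadable from compound 1 to compound 3 are both unreadable, since each pairs one limit with another.

Compound 4, `COC1=C(OC)[C@H](OC(C)=O)[C@H](C/C=C(\C)CC/C=C(\C)C[C@H](O)/C=C(\C)CO)[C@@H](C)C1=O`, differs from compound 1 in one place: acetyl in place of hydrogen on an oxygen on a saturated carbon. Among the measured compounds shown here, no measured step bears on this change, since none of the three compounds differs from another at that oxygen, and the two steps that do exist carry no readable size. For the measured compounds named here, what can be expected of compound 4 in this assay therefore rests only on the fact that every compound measured so far, compound 1 included, sits at the limit.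

On that basis compound 4 is expected to give about 30000 nM in this assay, with a likely range from 8000 nM to 120000 nM, and most probably only a limit again. The step of a number no higher from compound 1 to compound 4 (the limit leaves the size open) is thus estimated as no readable change.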

Compound 4, concentration for 50% growth inhibition: > 30000 nM
Compound 4: a limit, no number (the forecaster's own chance of this, stated with the estimate: 80%); the middle value sits exactly at the limit.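

Compound 4 gives only a limit, as compound 1 does, so the change from hydroxy to acetoxy yields no readable step between them: the limit of > 30000 nM in this assay, at which 4 of the 4 values shown sit. The compounds shown leave open how strongly compound 1, compound 2, compound 3 and compound 4 inhibit growth in this assay and whether any of these changes alters that strength.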